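The source may hold more compounds than are shown below. What is called first, only, known or untested is meant among the compounds shown, and "the series" means these compounds.

Measured compounds:

Compound 1, `Cn1nc(-c2ccccc2)c2cc(C(=N)Nc3ccccc3)ncc21`, gives 17400 nM.
Compound 2, `Cn1nc(-c2ccccc2)c2cc(C(=N)Nc3cccc(C(F)(F)F)c3)ncc21`, gives 17800 nM.
Compound 3, `N=C(Nc1ccccc1)c1cc2cn[nH]c2cn1`, is recorded as "not determined" (no result reported), so it has no reported result.

These three compounds were tested in a functional assay on HT-1080 cells (Homo sapiens) for cytotoxicity, read by MTT assay, with a stated time of 72 h; on this read-out higher numbers stand for weaker inhibition and lower numbers for stronger inhibition. Compound 1 and compound 2 share the same core and differ only in one place: trifluoromethyl in place of hydrogen on an aromatic carbon. The step between them, a 1.0-fold higher number from compound 1 to compound 2 (0.01 log units; within the scatter), shows that this change left the result essentially where it was, since the two numbers are within the scatter of each other. For compound 3 no single number is available in this assay, so nothing can be said about how it compares with compound 1. The difference between the core of compound 3 and the core of compound 1 is not broken down here.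

Compound 4, `N=C(Nc1cccc(C(F)(F)F)c1)c1cc2cn[nH]c2cn1`, has not yet been measured. It differs from compound 3 in one place: trifluoromethyl in place of hydrogen on an aromatic carbon. For the measured compounds named here, this is the same change as the one from compound 1 to compound 2, at the same kind of place. Going by the values given here, the only guide to its size is the step from compound 1 to compound 2, which stayed within the scatter, so a step of similar small size is expected from compound 3 to compound 4 in this assay. Compound 3 has no number, so the starting point for compound 4 is uncertain, and the estimate rests mainly on compound 1, which gives 17400 nM, as the nearest measured anchor with a related core.

Compound 4 is expected to give about 20000 nM in this assay, with a likely range from 5000 nM to 80000 nM.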

Compound 4, half-maximal inhibitory concentration: 36500 nM
The estimate for compound 4 lay 1.8-fold (0.26 log units) below the measured number; measured number inside the range.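

For the compounds shown here, compound 3 has no number in this assay, so no step from compound 3 to compound 4 can be read. The compounds shown leave open whether trifluoromethyl in place of hydrogen acts on the core of compound 3 as it does on the core of compound 1, where the step was a 1.0-fold higher number from compound 1 to compound 2 (0.01 log units; within the scatter). No measurement shown here offers an explanation for the result of compound 4.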